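The source may report more compounds than this note shows. Statements on the series, on what has been measured and on what is new or still open speak of the compounds shown alone.

Measured compounds:
Compound 1 `CN1C(=O)[C@@H](NC(=O)c2n[nH]c(Cc3ccccc3)n2)COc2ncccc21` – in an ADME assay on HT-29 cells (Homo sapiens) for cytotoxicity, read by luminescence and CellTiter-Glo, with a stated time of 10 h (on this read-out lower numbers stand for higher toxicity in this test and higher numbers for lower toxicity in this test), compound 1 gives > 50000 nM, which is a limit of the test rather than a number.
Compound 2 `Cc1cnc2c(c1)N(C)C(=O)[C@@H](NC(=O)c1n[nH]c(Cc3ccccc3)n1)CO2` – in this assay compound 2 gives > 50000 nM, again a limit.
Compound 3 `CN1C(=S)[C@@H](NC(=O)c2n[nH]c(Cc3ccccc3)n2)COc2ncccc21` – in this assay compound 3 gives > 50000 nM, also a limit.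

The study compares three compounds that share a bicyclic core carrying the same amide side chain. Compound 1 and compound 2 differ by one change, (methyl in place of hydrogen on an aromatic carbon). Among the measured compounds shown here, because both values sit at the limit of > 50000 nM in this assay, at which 3 of the 3 values shown sit, the step that the two limits leave unreadable from compound 1 to compound 2 cannot be read; the two limits say only that neither compound showed measurable toxicity here. Compound 3 has a different core; the difference between the two cores is not broken down here.

Compound 4 `Cc1cnc2c(c1)N(C)C(=S)[C@@H](NC(=O)c1n[nH]c(Cc3ccccc3)n1)CO2` has not yet been measured. It is obtained from compound 3 by the same change as before, (methyl in place of hydrogen on an aromatic carbon). The expectation rests on compound 3, whose value > 50000 nM is a limit, and on the unreadable step from compound 1 to compound 2. Compound 4 is therefore expected to show a step that the limit leaves unreadable from compound 3 to compound 4, and its expected value in this assay is 60000 nM, most likely again reported only as a limit.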

Compound 4, half-maximal cytotoxic concentration: > 50000 nM
Compound 4 gave a limit, no number (the forecaster's own chance of this, stated with the estimate: 85%); the middle value is on the limit's open side.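

No step can be read from compound 3 to compound 4, since both values are limits of the test and not numbers: the limit of > 50000 nM in this assay, at which 4 of the 4 values shown sit.

The compounds shown leave open whether methyl in place of hydrogen on an aromatic carbon changes toxicity at all in this assay, where none of the four gives a number.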